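A Pyridinyl Replacement in an Acetylated Sugar Enone Series

A few compounds are considered here, and "the series" means these few. Any claim that something is new, unique, unknown or untested is made for them only; others in the source may bear on it.

Within the data shown here, compound 2 `CC(=O)OC[C@H]1O[C@@H](CC(=O)/C=C/c2ccc(C(F)(F)F)cc2)[C@H](OC(C)=O)[C@@H](OC(C)=O)[C@@H]1OC(C)=O` is the one compound here with a measured number: in an ADME assay on cells (Epithelial cell, Homo sapiens) for cytotoxicity, read by MTT assay, with a stated time of 24 h (on this read-out lower numbers stand for higher toxicity in this test and higher numbers for lower toxicity in this test), compound 2 gives 103 nM. Compound 1 `CC(=O)OC[C@H]1O[C@@H](CC(=O)/C=C/c2cc(Cl)cc(Cl)c2O)[C@H](OC(C)=O)[C@@H](OC(C)=O)[C@@H]1OC(C)=O` gives "not determined" (no result reported) in this assay, and compound 3 `CC(=O)OC[C@H]1O[C@@H](CC(=O)/C=C/c2ccc([N+](=O)[O-])s2)[C@H](OC(C)=O)[C@@H](OC(C)=O)[C@@H]1OC(C)=O` likewise gives "not determined" (no result reported), so neither offers a comparison. Compound 4 `CC(=O)OC[C@H]1O[C@@H](CC(=O)/C=C/c2cccnc2)[C@H](OC(C)=O)[C@@H](OC(C)=O)[C@@H]1OC(C)=O` has not yet been measured. It differs from compound 2 in one place: pyridin-3-yl in place of 4-(trifluoromethyl)phenyl on a double-bonded chain carbon bound to a double-bonded chain carbon. Among the measured compounds shown here, no step between two measured compounds is available, so the size of the change in this assay is open. A modest step toward lower toxicity is expected, a 1.6-fold higher number from compound 2 to compound 4 (0.19 log units; within the scatter), though a result within the usual scatter would be no surprise. Compound 4 is estimated at 160 nM, within a range from 40 nM to 650 nM.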

Compound 4, half-maximal cytotoxic concentration: 4.17 nM
Compound 4: middle estimate off by 38-fold (1.58 log units), on the high side; the measured number lies below the stated range.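

Replacing 4-(trifluoromethyl)phenyl with pyridin-3-yl on a double-bonded chain carbon bound to a double-bonded chain carbon gives a 25-fold lower number from compound 2 to compound 4 (1.39 log units; beyond the scatter) in this assay. This position therefore has a strong influence on the read-out, and compound 4 is the more toxic in this test. Nothing available here explains the step.

The compounds shown leave open whether the step comes from gaining the ring nitrogen or from losing the trifluoromethyl group. An unsubstituted phenyl ring at this place would help separate the two.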